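Trading a Pyridine for a Methylpyrazole in a Cytotoxicity Series

The source may report more compounds than this note shows. Statements on the series, on what has been measured and on what is new or still open speak of the compounds shown alone.

Measured so far:
Compound 1, `CN(C)CCCCOC(=O)Nc1ccc(Cn2nc(-c3ccncc3)c3ccccc3c2=O)cc1`, gives 62700 nM.
Compound 2, `CN(C)CCCCOC(=O)Nc1ccc(Cn2nc(-c3cccnc3)c3ccccc3c2=O)cc1`, gives 68000 nM.

Both numbers come from an ADME assay on Huh-7 cells (Homo sapiens) for cytotoxicity, read by MTT assay, with a stated time of 48 h; on this read-out lower numbers stand for higher toxicity in this test and higher numbers for lower toxicity in this test. Compound 2 stands level with compound 1 on these numbers, since a 1.1-fold higher number from compound 1 to compound 2 (0.04 log units; within the scatter) lies within the scatter. Compound 3, `CN(C)CCCCOC(=O)Nc1ccc(Cn2nc(-c3cnn(C)c3)c3ccccc3c2=O)cc1`, is the next candidate; its change from compound 2 is 1-methyl-1H-pyrazol-4-yl in place of pyridin-3-yl on an aromatic carbon. For the measured compounds named here, only one measured step bears on this kind of exchange, one small aromatic group replaced by another of the same size, and that step stayed within the scatter. No shift beyond the scatter is therefore expected, a 1.0-fold lower number from compound 2 to compound 3 (0.02 log units; within the scatter). Compound 3 is estimated at 65000 nM, within a range from 30000 nM to 140000 nM.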

Compound 3, half-maximal cytotoxic concentration: 55900 nM
For compound 3 the middle estimate is 1.2-fold (0.07 log units) above the measured one; measured number inside the range.
By their numbers in this assay, from the lowest: compounds 3, 1 and 2 (each within the scatter of the next).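

In this assay, the step (a 1.2-fold lower number from compound 2 to compound 3 (0.09 log units; within the scatter)) and the step (a 1.1-fold lower number from compound 1 to compound 3 (0.05 log units; within the scatter)) show that this place on the shared core accepts a five-membered aromatic ring as well as a six-membered one, with the numbers staying within the scatter. Swapping ring size and adding a second ring nitrogen, along with the methyl on it, thus leaves the read-out level across these three compounds. Nothing at hand explains this. Still open, going by these compounds, is whether a plain phenyl ring, a carboxylic acid or a morpholine at this place would also leave the number level. The compounds shown also leave open whether a shorter chain in place of the dimethylaminobutyl chain would change it.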